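The source may report more compounds than this note shows. Statements on the series, on what has been measured and on what is new or still open speak of the compounds shown alone.

Measured compounds:
Compound 1, `Cc1cc(O)c(C2=NN(c3ccc(S(N)(=O)=O)cc3)C(/C=C/c3ccccc3)C2)cc1Cl`
Compound 2, `COc1ccc(C2CC(c3cc(Cl)c(C)cc3O)=NN2c2ccc(S(N)(=O)=O)cc2)cc1OC`

In a functional assay on SF-268 cells (Homo sapiens) for antiproliferative activity, with a stated time of 48 h (on this read-out higher numbers stand for weaker inhibition of growth and lower numbers for stronger inhibition of growth), compound 1 gives 5630 nM. In this assay compound 2 gives 4740 nM. For the measured compounds named here, the single step between them, a 1.2-fold lower number from compound 1 to compound 2 (0.07 log units; within the scatter), is within the scatter, so compound 2 stands apart from compound 1 by no more than repeated measurements usually vary. Compound 3, `COc1ccc(C2CC(c3cc(Cl)c(C)cc3O)=NN2c2ccc(S(N)(=O)=O)cc2)c(OC)c1OC`, differs from compound 2 by methoxy in place of hydrogen on an aromatic carbon. Going by the values given here, no measured step touches that position; the only step at hand replaces the whole group on the saturated ring carbon and, being within the scatter, offers little to build on. A further methoxy on an aromatic ring that already carries two is therefore expected to leave this assay nearly unchanged, with no step beyond the scatter in either direction. For compound 3 the estimate is 4200 nM, in the range 1500 nM to 12000 nM, a step of a 1.1-fold lower number from compound 2 to compound 3 (0.05 log units; within the scatter) that is expected to stay within the scatter.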

Compound 3, concentration for 50% growth inhibition: 4290 nM
For compound 3 the middle estimate is 1.0-fold (0.01 log units) below the measured one, and the stated range covers the measured number.
By their numbers in this assay, from the lowest: compounds 3, 2 and 1 (each within the scatter of the next).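

For the compounds shown here, with 3,4-dimethoxyphenyl going to 2,3,4-trimethoxyphenyl, methoxy enters on an aromatic carbon ortho to a large group, a place no earlier step touched, and in this assay the step (a 1.1-fold lower number from compound 2 to compound 3 (0.04 log units; within the scatter)) shows that this position takes the added methoxy without a move beyond the scatter. Exchanging the whole group on the saturated ring carbon, 2,3,4-trimethoxyphenyl in place of 2-phenylethenyl, also stays within the scatter (a 1.3-fold lower number from compound 1 to compound 3 (0.12 log units; within the scatter)), so the three compounds do not separate in this assay. Nothing independent of these numbers bears on this result.

The compounds shown leave open whether an amine or a carboxylic acid on this same aromatic carbon would give a step beyond the scatter. They also leave open what a longer chain, such as butoxy, would do there in place of methoxy.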